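This account rests on a few compounds, and the source may have more. Where it says the series, first, only, none or still open, it means among the compounds named here.

Measured compounds:
- compound 1 `COc1cccc(/C=C2\Cc3ccccc3C2=O)c1OC`, 28700 nM
- compound 2 `O=C1/C(=C/c2ccccc2Cl)Cc2ccccc21`, 26500 nM

In a functional assay on P388 cells (Mus musculus) for inhibition (on this read-out higher numbers stand for weaker inhibition and lower numbers for stronger inhibition), compound 2 holds the lower of the two numbers, but its gap to compound 1 lies within the scatter, so the two stand together at weak inhibition. Compound 3 `O=C1/C(=C/c2ccccc2F)Cc2ccccc21` differs from compound 2 by fluoro in place of chloro on an aromatic carbon. Within the data shown here, no pair among the measured compounds shows this change, so its size cannot be read from the data. The expected step is none beyond the scatter, a 1.1-fold higher number from compound 2 to compound 3 (0.05 log units; within the scatter). For compound 3 the estimate in this assay is 30000 nM, with a range from 12000 nM to 75000 nM.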

Compound 3, half-maximal inhibitory concentration: 31700 nM
Estimate against measurement, compound 3: 1.1-fold (0.02 log units) below; low and high end bracket the measured number.
By their numbers in this assay, from the lowest: compounds 2, 1 and 3 (each within the scatter of the next).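

In this assay, fluoro in place of chloro on an aromatic carbon, ortho to a large group, gives a 1.2-fold higher number from compound 2 to compound 3 (0.08 log units; within the scatter), the first measured size for this change in the series. At this place, the two halogens therefore cannot be told apart on this read-out. No measured property bears on this result.

Still open, going by these compounds, is whether a group of another kind at this place, such as an amine or a carboxylic acid, would move the number beyond the scatter. Also open, on these data alone, is whether the same exchange behaves alike elsewhere on this ring.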